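Anilide series: oxime-bearing acyl group in place of pyranone

A few compounds are considered here, and "the series" means these few. Any claim that something is new, unique, unknown or untested is made for them only; others in the source may bear on it.

Measured so far:
Compound 1 `O=C(CCCCCCNC(=O)C(O)(O)C(F)(F)F)Nc1nc2ccc(Br)cc2o1` gives 12100 nM in a functional assay on HCT-116 cells (Homo sapiens) for inhibition, read by colorimetric assay, with a stated time of 3 days; on this read-out lower numbers stand for stronger inhibition and higher numbers for weaker inhibition.
Compound 3 `CC(=O)c1ccc(NC(=O)CCCCCCNC(=O)C(O)(O)C(F)(F)F)cc1` gives 12100 nM in this assay.
Compound 2 `O=C(CCCCNC(=O)c1cc(=O)c(O)co1)Nc1ccccc1` returns only a limit in this assay, > 100000 nM.

Within the data shown here, compound 2 stands at the edge of the measured range: its result is a limit of the assay, not a number, and it is the one value of the three that sits there (the limit of > 100000 nM in this assay, at which 1 of the 3 values shown sits). Among the measured compounds shown here, compound 1 and compound 3 give readings that lie within the usual scatter of each other; both carry a different acyl group on a longer chain than compound 2, so no single-point step links them to it.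

Compound 4 `C/C(=N\O)C(=O)NCCCCC(=O)Nc1ccccc1` is the next compound to be measured. It differs from compound 2 in one place: a group of 4 heavy atoms (2 carbon, 1 nitrogen, 1 oxygen; no ring) in place of a group of 8 heavy atoms (5 carbon, 3 oxygen; one six-membered aromatic ring with 1 hetero atom), on a carbonyl carbon. The anilide and the chain to the amide nitrogen are kept unchanged.

For the measured compounds named here, no step between measured compounds exists to calibrate this change. Since compound 2 is a limit, the direction of the step cannot be read from the data, and an outcome at the limit again is plausible. The expected step of an at least 1.6-fold lower number from compound 2 to compound 4 (0.22 log units; that floor lies within the scatter) in this assay is therefore set loosely. Compound 4 is expected at 60000 nM, within a range from 10000 nM to 300000 nM.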

Compound 4, half-maximal inhibitory concentration: > 100000 nM
Compound 4 ended at the assay's limit (the forecaster's own chance of this, stated with the estimate: 55%); at least 1.6-fold (0.22 log units) between middle value and limit.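

In this assay compound 2 gives > 100000 nM, a limit of the assay. Compound 4 gives > 100000 nM, also a limit. No step can be read between compound 2 and compound 4, as both results sit at the same edge of the range: the limit of > 100000 nM in this assay, at which 2 of the 4 values shown sit. The compounds shown leave open whether the two acyl groups differ at all in this assay.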